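The compounds below may be only part of what the source reports. "The series", "measured", "known", "first", "only" and "open" are said of these compounds alone.

Compound 1, `c1ccc2c(c1)CCC2CCCN1CCN(c2cccc3c2OCCO3)CC1`: 10 mg/kg in a functional assay on the whole organism for agonist activity, with Rattus norvegicus as the target; a higher number here means that more compound is needed for the effect, a lower number that less compound is needed.
Compound 2, `Clc1cccc2c1CC2CCCN1CCN(c2cccc3c2OCCO3)CC1`: > 10 mg/kg in this assay, a limit of the assay and not a number.

Compound 2 thus stands at the limit of > 10 mg/kg in this assay, at which 1 of the 2 values shown sits; how far it lies from the dose found for compound 1 cannot be read. For the measured compounds named here, the only measured step, a number no lower from compound 1 to compound 2 (the limit leaves the size open), runs the other way and leaves its size open, so it sets a direction but no amount. Compound 3, `c1ccc2c(c1)CC(CCCN1CCN(c3cccc4c3OCCO4)CC1)C2`, arises from compound 2 by the change (a group of 9 heavy atoms (9 carbon; one five-membered non-aromatic ring of carbon only, one six-membered aromatic ring of carbon only) in place of a group of 9 heavy atoms (8 carbon, 1 chlorine; one four-membered non-aromatic ring of carbon only, one six-membered aromatic ring of carbon only), on a saturated chain carbon, three bonds along the chain from an amine nitrogen in a ring). Going by the values given here, this change brings back the five-membered non-aromatic ring of carbon only that compound 1 carries and removes the chlorine together with the four-membered ring. The step of a number no higher from compound 2 to compound 3 (the limit leaves the size open) is expected to run toward a lower dose or to stay within the scatter, its size not fixable from an open-ended limit. On that footing compound 3 is expected in this assay to give 10 mg/kg, with a range from 3 mg/kg to 30 mg/kg, the value of compound 1 being the nearest guide.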

Compound 3, minimum effective dose: 40 mg/kg
Compound 3: the middle estimate sits 4.0-fold (0.60 log units) below what was measured; the measured number lies above the stated range.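

Compared with the earlier pair, whose only step gave a direction, this result puts a readable size on a change at this position. In this assay, 2,3-dihydro-1H-inden-2-yl in place of 2,3-dihydro-1H-inden-1-yl, on a saturated chain carbon, three bonds along the chain from an amine nitrogen in a ring, gives a 4.0-fold higher number from compound 1 to compound 3 (0.60 log units; beyond the scatter); both groups hold nine carbon atoms and the same two rings, so the dose here shifts with the point of attachment of the group alone. Compound 2 gives only a limit, so neither its step from compound 1 nor its step to compound 3 has a size that can be read: the limit of > 10 mg/kg in this assay, at which 1 of the 3 values shown sits.

The compounds shown leave open how much of the change in compound 2 belongs to the chlorine and how much to the four-membered ring, since the two change together there. They also leave open how a chlorine on 2,3-dihydro-1H-inden-1-yl, a plain cyclohexyl group at this place or a longer chain to the amine nitrogen would fare in this assay.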